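Cyclohexyl for chlorophenyl: tolerance in THP-1 cells

The compounds below may be only part of what the source reports. "The series", "measured", "known", "first", "only" and "open" are said of these compounds alone.

Measured so far in a toxicity assay on THP-1 cells (Homo sapiens) for inhibition; a higher number here means that more compound is tolerated, a lower number that less compound is tolerated:
- compound 1 `COc1ccc(-c2cnc(NC(=O)c3cccc(Cl)c3)n2C)cc1` gives > 28000 nM, a limit of the assay.
- compound 2 `COc1ccc(-c2cnc(NC(=O)C3CCCCC3)n2C)cc1` gives > 100000 nM, a limit of the assay.
- compound 3 `Cn1c(-c2ccccc2)cnc1NC(=O)c1cccc(Cl)c1` gives > 50000 nM, a limit of the assay.

Among the measured compounds shown here, all three values are limits, so no step among them can be read. The change cyclohexyl in place of 3-chlorophenyl on a carbonyl carbon gives a step that the two limits leave unreadable from compound 1 to compound 2, since both compounds sit at limits, the limit of > 28000 nM in this assay, at which 1 of the 3 values shown sits, and (the limit of > 100000 nM in this assay, at which 1 of the 3 values shown sits). The two cores differ by hydrogen in place of methoxy on an aromatic carbon, and that step reads a step that the two limits leave unreadable from compound 1 to compound 3, with compound 3 at the limit of > 50000 nM in this assay, at which 1 of the 3 values shown sits.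

Compound 4 `Cn1c(-c2ccccc2)cnc1NC(=O)C1CCCCC1` is not yet measured. It differs from compound 3 by cyclohexyl in place of 3-chlorophenyl on a carbonyl carbon, the same kind of change as from compound 1 to compound 2, made at a place described in the same words. Because compound 1 and compound 2 both sit at limits, the limit of > 28000 nM in this assay, at which 1 of the 3 values shown sits, and (the limit of > 100000 nM in this assay, at which 1 of the 3 values shown sits), the step from compound 3 to compound 4 in this assay is expected to stay unreadable, and the expected step that the limit leaves unreadable from compound 3 to compound 4 is nominal. Compound 4 is estimated at 100000 nM, between 30000 nM and 300000 nM.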

Compound 4, half-maximal cytotoxic concentration: > 100000 nM
Compound 4 was reported as a limit; the forecaster's own chance of this, stated with the estimate: 85%; the middle value sits exactly at the limit.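

In this assay compound 4 gives > 100000 nM, a limit of the assay. Compound 2 and compound 3 also sit at limits, and the steps from each of them to compound 4 cannot be read. The compounds shown leave open whether cyclohexyl in place of 3-chlorophenyl, or hydrogen in place of methoxy, changes tolerance at all.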